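Working notes: from compound 2 to compound 4

The source may report more compounds than this note shows. Statements on the series, on what has been measured and on what is new or still open speak of the compounds shown alone.

Compound 2 `CN(Cc1ccccc1)C(=O)c1ccc(-c2cc(C3=CC(=O)C=CC3=O)no2)s1` was tested in a functional assay on A549 cells (Homo sapiens) for cytotoxicity, read by XTT assay, with a stated time of 72 h; a lower number here means a stronger inhibitor, a higher number a weaker inhibitor. Compound 2 gives > 30000 nM, which is a limit and not a number. Compound 1 `CCCN(C)C(=O)c1ccc(-c2cc(-c3cc(OC)ccc3OC)no2)s1` gives > 30000 nM, also a limit. Compound 3 `COc1ccc(OC)c(-c2cc(-c3ccc(C(=O)N(C)Cc4ccccc4)s3)on2)c1` gives > 30000 nM, again a limit. For the measured compounds named here, the series so far therefore rests on (the limit of > 30000 nM in this assay, at which 3 of the 3 values shown sit), and compound 2 has no measured number to start from.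

Compound 4 `O=C1C=CC(=O)C(c2cc(-c3ccc(C(=O)NCC4CC4)s3)on2)=C1` carries (cyclopropylmethyl)amino in place of benzyl(methyl)amino on a carbonyl carbon.

Going by the values given here, two measured steps bear on this change. The closer in kind is a step that the two limits leave unreadable from compound 1 to compound 3, which also alters a group on an amide-type nitrogen. The other is a step that the two limits leave unreadable from compound 2 to compound 3, which alters a different place, on an aromatic carbon. Each has a limit at both ends, so neither gives a size to carry over to compound 4.

With no readable step behind it, no large move is expected in this assay. At most a small shift towards stronger inhibition is expected, and a further limit remains more likely than a number. The expected step is an at least 1.2-fold lower number from compound 2 to compound 4 (0.07 log units; that floor lies within the scatter). For compound 4 the estimate is 25000 nM, with an expected range from 5000 nM to 50000 nM.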

Compound 4, half-maximal inhibitory concentration: > 30000 nM
Compound 4 gave a limit, no number (the forecaster's own chance of this, stated with the estimate: 60%); at least 1.2-fold (0.07 log units) between middle value and limit.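

In this assay compound 4 gives > 30000 nM, a limit and not a number. Compound 2 is also only a limit, so no step can be read between compound 2 and compound 4. Whether (cyclopropylmethyl)amino in place of benzyl(methyl)amino changes the read-out at all stays open, because the series offers no measured number to compare: the limit of > 30000 nM in this assay, at which 4 of the 4 values shown sit.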